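Sulfonyl aryl swap in a two-compound series

The compounds below may be only part of what the source reports. "The series", "measured", "known", "first", "only" and "open" are said of these compounds alone.

In a functional assay on MCF7 cells (Homo sapiens) for antiproliferative activity, read by MTT assay, with a stated time of 48 h (a higher number here means a weaker inhibitor, a lower number a stronger inhibitor), compound 1 `Cc1ccc(S(=O)(=O)n2cc(/C=C/C(=O)c3ccncc3)c3ccccc32)cc1` gives 48900 nM and compound 2 `COc1ccc(S(=O)(=O)n2cc(/C=C/C(=O)c3ccncc3)c3ccccc32)cc1` gives 65800 nM, so compound 2 stands level with compound 1 within the scatter. Compound 3 `O=C(/C=C/c1cn(S(=O)(=O)c2ccccc2[N+](=O)[O-])c2ccccc12)c1ccncc1` carries a new group on the sulfonyl sulfur: 2-nitrophenyl in place of 4-methoxyphenyl on a sulfonyl sulfur. For the measured compounds named here, the only measured step bearing on this, a 1.3-fold higher number from compound 1 to compound 2 (0.13 log units; within the scatter), is a swap of methoxy for methyl and stays within the scatter, so it gives weak guidance. No shift beyond the scatter is expected in this assay, and the estimated change is a 1.3-fold lower number from compound 2 to compound 3 (0.12 log units; within the scatter). Compound 3 is expected at 50000 nM, with an estimated range of 20000 nM to 120000 nM.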

Compound 3, half-maximal inhibitory concentration: 36900 nM
Beside the measured number, compound 3's estimate is 1.4-fold (0.13 log units) above it; low and high end bracket the measured number.
By their numbers in this assay, from the lowest: compounds 3, 1 and 2 (each within the scatter of the next).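

In this assay, 2-nitrophenyl on the sulfonyl sulfur gives a 1.8-fold lower number from compound 2 to compound 3 (0.25 log units; within the scatter), and against 4-methylphenyl it gives a 1.3-fold lower number from compound 1 to compound 3 (0.12 log units; within the scatter). For the compounds shown here, this position therefore takes a third aryl group, now one with a different substituent and substitution pattern, and no step among compounds 1, 2 and 3 leaves the scatter. No supporting evidence bears on this result. Going by these compounds, it remains open whether an amine or a carboxylic acid on this aryl ring, or a simple alkyl chain in its place on the sulfonyl sulfur, would move the number beyond the scatter.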